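Amino to hydroxy on two cores that show no cytotoxicity

The source may report more compounds than this note shows. Statements on the series, on what has been measured and on what is new or still open speak of the compounds shown alone.

Compound 1, `Nc1ncnc2c1ncn2[C@@H]1CCC[C@H]1CO`: in an ADME assay on L1210/0 cells (Mus musculus) for cytotoxicity, with a stated time of 48 h (a lower number here means a stronger inhibitor, a higher number a weaker inhibitor), compound 1 gives > 200000 nM, which is a limit of the assay.
Compound 2, `Nc1nc2c(nc(N)n2COCCO)c(=O)[nH]1`: in this assay compound 2 gives > 200000 nM, again a limit.
Compound 3, `Nc1nc2c(nc(O)n2COCCO)c(=O)[nH]1`: in this assay compound 3 gives > 200000 nM, also a limit.

Compound 3 differs from compound 2 in one place, (hydroxy in place of amino on an aromatic carbon). Going by these compounds, the measured step is a step that the two limits leave unreadable from compound 2 to compound 3, so its size stays unknown. Compound 4, `OC[C@@H]1CCC[C@H]1n1cnc2c(O)ncnc21`, has not been measured in this assay. It stands to compound 1 as compound 3 stands to compound 2: hydroxy in place of amino on an aromatic carbon. How the core of compound 1 differs from the core of compound 2 is not broken down here. The surroundings of the change differ as well: in compound 2 it sits on a five-membered aromatic ring with 2 nitrogen, between two ring nitrogen atoms, next to the ring atom that bears a (2-hydroxyethoxy)methyl group, whereas in compound 1 it sits on a six-membered aromatic ring with 2 nitrogen, next to the ring nitrogen, ortho to a fused ring, meta to a fused ring, opposite the ring nitrogen. It is therefore the same kind of change, not the same change.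

Because the limit of > 200000 nM in this assay, at which 3 of the 3 values shown sit, holds for compound 1 as for every value shown, the step to compound 4 is expected to be a number no higher from compound 1 to compound 4 (the limit leaves the size open). Compound 4 is estimated at about 200000 nM in this assay, between 50000 nM and 600000 nM, and is expected most likely to come back as a limit again.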

Compound 4, half-maximal inhibitory concentration: > 200000 nM
Compound 4 gave a limit, no number; the forecaster's own chance of this, stated with the estimate: 85%; the middle value sits exactly at the limit.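

In this assay compound 4 gives > 200000 nM, which is a limit of the assay and not a number. For the compounds shown here, compound 1 also stands at a limit, so no step between compound 1 and compound 4 can be read. The compounds shown leave open whether hydroxy in place of amino on an aromatic carbon alters the result on either core, since every value is a limit: the limit of > 200000 nM in this assay, at which 4 of the 4 values shown sit.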